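Ethoxyphenyl series: ester to amide at the carbonyl

The source may hold more compounds than are shown below. What is called first, only, known or untested is meant among the compounds shown, and "the series" means these compounds.

Measured so far:
compound 1 `CCOc1ccc(-c2cccc(S(=O)(=O)NC)c2)cc1` 47%
compound 2 `CCOc1ccc(-c2cccc(C)c2)cc1` 54%
compound 3 `CCOc1ccc(-c2cccc(C(=O)OCC(F)(F)F)c2)cc1` 71%

In an assay on COS-7 cells for inhibition of patatin-like phospholipase domain-containing protein 2 (Mus musculus), tested at 200 uM (on this read-out higher numbers stand for more inhibition at the one concentration tested (going by the name of the read-out) and lower numbers for less inhibition), compound 3 gives the highest of the three numbers; the nearest is compound 2, and the gap to compound 1 is the widest, both beyond the scatter. Among the measured compounds shown here, the only counted step, a number 7 percentage points higher from compound 1 to compound 2 (within the scatter), is within the scatter and does not touch the carbonyl position. Compound 4 `CCNC(=O)c1cccc(-c2ccc(OCC)cc2)c1` differs from compound 3 by ethylamino in place of 2,2,2-trifluoroethoxy on a carbonyl carbon. For the measured compounds named here, no measured step covers a change at that place; the other member carrying a hydrogen-bond donor, compound 1, gives 47% in this assay, while compound 3 gives 71%. Going by the values given here, with no direct precedent, a modest fall is expected, a number 16 percentage points lower from compound 3 to compound 4 (beyond the scatter), with wide uncertainty. Compound 4 is therefore estimated at 55% in this assay, within 35% to 75%.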

Compound 4, a percentage reported as inhibition, at one concentration (the size of the read-out at that concentration, not a potency): 62%
The estimate for compound 4 lay 7 percentage points below the measured number; the range from low to high includes it.
By their numbers in this assay, from the lowest: compounds 1, 2, 4 and 3 (each within the scatter of the next, the first and the last beyond it).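

In this assay, the carbonyl carbon accepts ethylamino in place of 2,2,2-trifluoroethoxy, with a number 9 percentage points lower from compound 3 to compound 4 (within the scatter). On the aromatic carbon, ethylcarbamoyl is separated from methylsulfamoyl, with a number 15 percentage points higher from compound 1 to compound 4 (beyond the scatter), but not from methyl, with a number 8 percentage points higher from compound 2 to compound 4 (within the scatter). Nothing available bears on why these steps take this size.

As far as these compounds go, a carboxylic acid or a longer chain on the carbonyl carbon remains open. So does the part played by the amide hydrogen, on which dimethylamino at that carbon would bear.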